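Carbamates in Alkaline Buffer: Ring to Chain on Nitrogen

The source may report more compounds than this note shows. Statements on the series, on what has been measured and on what is new or still open speak of the compounds shown alone.

Compound 1 `O=C(NC1CCCCC1)Oc1cccc(-c2ccccc2)c1` gives 0.678 h in a physicochemical assay for pharmacokinetics, read by HPLC, at pH 9.0; a lower number here means that the compound disappears faster, a higher number that the compound lasts longer.
Compound 2 `O=C(NC1CCCC1)Oc1cccc(-c2ccccc2)c1` gives 0.752 h in this assay.
Compound 3 `O=C(NCc1ccc2ccccc2c1)Oc1cccc(-c2ccccc2)c1` gives 0.398 h in this assay.

Compound 1 holds the second highest of the three half-lives shown. Its nearest neighbour is compound 2, with a 1.1-fold higher number from compound 1 to compound 2 (0.04 log units; within the scatter), a change that stays within the scatter. Compound 3 sits furthest from compound 1, yet the gap between the two values also stays within the scatter, so no order among the three can be claimed.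

The step now followed leads to compound 4 `CCCCNC(=O)Oc1cccc(-c2ccccc2)c1`. Compared with compound 1 the change is butyl in place of cyclohexyl on an amide-type nitrogen. For the measured compounds named here, the only measured step that bears on it is the one from compound 1 to compound 2, which swaps one ring for another on the same nitrogen and moves the half-life by an amount within the scatter. Going by the values given here, no measured pair opens a ring into a chain, so the data give no direct guide for that part of the change.

Compound 4 is therefore expected to lie close to compound 1, with a step of a 1.1-fold lower number from compound 1 to compound 4 (0.04 log units; within the scatter) that is not expected to exceed the scatter. The estimate for compound 4 is 0.62 h, with a range from 0.35 h to 1.1 h.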

Compound 4, half-life: 0.715 h
For compound 4 the middle estimate is 1.2-fold (0.06 log units) below the measured one; low and high end bracket the measured number.
By their numbers in this assay, from the lowest: compounds 3, 1, 4 and 2 (each within the scatter of the next).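

For the compounds shown here, until now the only comparison on the amide-type nitrogen was one ring against another, and compound 4 adds an open chain to it. In this assay the step to butyl from cyclohexyl is a 1.1-fold higher number from compound 1 to compound 4 (0.02 log units; within the scatter) and the step to butyl from cyclopentyl is a 1.1-fold lower number from compound 2 to compound 4 (0.02 log units; within the scatter) so these two rings and the chain cannot be told apart at this position. No measurement shown gives a reason for this result.

On these data alone, whether a chain longer than butyl, or a butyl chain ending in an amine or a carboxylic acid, would also stay within the scatter of compound 4 in this assay remains open. So does the effect of a branched chain such as tert-butyl on the same nitrogen.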